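Hydroxy in place of methoxy on a pyrazole series

The source may report more compounds than this note shows. Statements on the series, on what has been measured and on what is new or still open speak of the compounds shown alone.

Of the compounds shown here, three share one core and have been tested in a functional assay on 786-0 cells (Homo sapiens) for cytotoxicity, read by sulforhodamine B assay, with a stated time of 48 h, tested at 1 uM; a higher number here means a weaker effect of the compound at the concentration tested, a lower number a stronger effect. Compound 1 `COc1cc(C)cc(-c2c(-c3ccnc(-c4ccc(C(C)=O)cc4)c3)cnn2CC#N)c1` gives 10%, compound 2 `Cc1cc(O)cc(-c2nn(CC#N)cc2-c2ccnc(-c3ccc(Oc4ccccc4)cc3)c2)c1` gives -34%, and compound 3 `COc1cc(C)cc(-c2nn(CC#N)cc2-c2ccnc(-c3ccc(N(C)C)cc3)c2)c1` gives -8%. Compound 3 thus stands second highest of the three, beyond the scatter from both neighbours: compound 1 sits higher and compound 2 lower. Compound 4 `Cc1cc(O)cc(-c2nn(CC#N)cc2-c2ccnc(-c3ccc(N(C)C)cc3)c2)c1` has not been measured. It differs from compound 3 by hydrogen in place of methyl on an oxygen on an aromatic ring. Within the data shown here, no step between measured compounds isolates this change, so the size is uncertain; a small downward shift, or none beyond the scatter, is expected, as a number 7 percentage points lower from compound 3 to compound 4 (within the scatter). Compound 4 is estimated at -15%, within -40% to 10%.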

Compound 4, a percentage reported as activity, at one concentration (the size of the read-out at that concentration, not a potency): 14%
Beside the measured number, compound 4's estimate is 29 percentage points below it; measured number above the stated range.
By their numbers in this assay, from the lowest: compound 2; then compound 3; then compounds 1 and 4 (each within the scatter of the next).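

In this assay the change from methoxy to hydroxy now has its first single-change reading, a number 22 percentage points higher from compound 3 to compound 4 (beyond the scatter), so at this place hydrogen in place of methyl on the oxygen weakens the effect at the concentration tested. With the hydroxy held, the step of a number 48 percentage points higher from compound 2 to compound 4 (beyond the scatter) shows that dimethylamino in place of phenoxy on an aromatic carbon also moves the read-out strongly. Nothing at hand explains either step.

On these data alone, whether the methoxy to hydroxy step keeps its direction with phenoxy in place of dimethylamino stays open. So does what an ethoxy or an amino group would give on that aromatic ring.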